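Ethoxy for carbamoyl on the saturated ring carbon

The compounds below may be only part of what the source reports. "The series", "measured", "known", "first", "only" and "open" are said of these compounds alone.

Measured so far:
compound 1, `CCO[C@H]1C[C@@H](c2coc3ccc(Br)cc3c2=O)N(c2ccccc2)O1`: > 60000 nM
compound 2, `NC(=O)[C@H]1C[C@@H](c2coc3ccccc3c2=O)N(c2ccccc2)O1`: > 60000 nM

Both values come from a functional assay on Caco-2 cells (Homo sapiens) for inhibition, read by sulforhodamine B assay, with a stated time of 48 h; a higher number here means a weaker inhibitor, a lower number a stronger inhibitor. For compound 1 the result is only a limit of the assay, > 60000 nM. For compound 2 the result is likewise only a limit, > 60000 nM, so no number is known for compound 2 and its standing on the shown values cannot be ranked; what is known is the limit of > 60000 nM in this assay, at which 2 of the 2 values shown sit.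

Compound 3, `CCO[C@H]1C[C@@H](c2coc3ccccc3c2=O)N(c2ccccc2)O1`, has not yet been measured in this assay. It differs from compound 2 in one place: ethoxy in place of carbamoyl on a saturated ring carbon. Going by the values given here, no step between two measured compounds is available, so the size of this exchange in this assay is not known from the data.

Given that compound 2 sits at a limit, > 60000 nM, compound 3 is expected to give a similar limit or a weak value, with a step of a number no higher from compound 2 to compound 3 (the limit leaves the size open) expected to stay within the scatter. The estimate for compound 3 in this assay is 60000 nM, with a range from 20000 nM to 200000 nM.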

Compound 3, half-maximal inhibitory concentration: > 60000 nM
Compound 3: a limit, no number (the forecaster's own chance of this, stated with the estimate: 75%); the middle value sits exactly at the limit.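

In this assay compound 3 gives only a limit, > 60000 nM. The steps to compound 3 from compound 2 and from compound 1 therefore cannot be read. The compounds shown leave open whether ethoxy in place of carbamoyl, or hydrogen in place of bromo, alters inhibition at all, since all three rest at one limit: the limit of > 60000 nM in this assay, at which 3 of the 3 values shown sit.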